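The compounds below may be only part of what the source reports. "The series", "measured", "known", "first", "only" and "open" are said of these compounds alone.

Measured so far:
- compound 1 `COc1ccc2[nH]c(C(=O)N3CC(=O)N(Cc4ccccc4)[C@@H](CN4CCC5(CC4)CC5)C3)cc2c1` — 0.867 h
- compound 2 `COc1ccc2[nH]c(C(=O)N3CC(=O)N(Cc4ccccc4)[C@@H](CN4CCC(C(C)C)CC4)C3)cc2c1` — 0.317 h

In an ADME assay on microsomes from liver (Homo sapiens) for metabolic stability, with a stated time of 30 min, tested at 1 uM (a higher number here means that the compound lasts longer, a lower number that the compound disappears faster), compound 2 gives the lowest of the two numbers; compound 1 sits above it, and the step of a 2.7-fold lower number from compound 1 to compound 2 (0.44 log units; beyond the scatter) lies beyond the scatter. Compound 3 `COc1ccc2[nH]c(C(=O)N3CC(=O)N(Cc4ccccc4)[C@@H](CN4CCc5ccccc5C4)C3)cc2c1` differs from compound 2 by 1,2,3,4-tetrahydroisoquinolin-2-yl in place of 4-isopropylpiperidin-1-yl on a saturated chain carbon bound to a saturated ring carbon. Going by the values given here, only the step from compound 1 to compound 2 touches this position, and it changed a saturated ring group for another saturated ring group, whereas here an aromatic ring enters. That step therefore gives no firm direction, only a hint that changes at this position can move this assay by a modest amount. The expected step of a 1.2-fold higher number from compound 2 to compound 3 (0.08 log units; within the scatter) is accordingly small and uncertain, with no clear direction beyond the scatter. Compound 3 is estimated at 0.38 h, within a range of 0.15 h to 1 h.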

Compound 3, half-life: 0.617 h
Estimate against measurement, compound 3: 1.6-fold (0.21 log units) below; measured number inside the range.
By their numbers in this assay, from the lowest: compounds 2, 3 and 1 (each within the scatter of the next, the first and the last beyond it).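

In this assay, going by these compounds alone, an aromatic ring now stands for the first time on a saturated chain carbon bound to a saturated ring carbon, and the outcome cannot be told apart from 4-isopropylpiperidin-1-yl (step: a 1.9-fold higher number from compound 2 to compound 3 (0.29 log units; within the scatter)). The comparison with the group of compound 1 is equally unresolved (step: a 1.4-fold lower number from compound 1 to compound 3 (0.15 log units; within the scatter)), so 1,2,3,4-tetrahydroisoquinolin-2-yl is not separated from either saturated group, although those two are separated from each other. No measurement at hand accounts for these numbers.

The compounds shown leave open whether the fused aromatic ring matters as such, which an unfused 4-phenylpiperidin-1-yl group would help to show. They also leave open what a second hetero atom in the ring would do, as in morpholin-4-yl or piperazin-1-yl.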